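From anilide to pyridylmethyl amide: a lipophilicity estimate

The source may hold more compounds than are shown below. What is called first, only, known or untested is meant among the compounds shown, and "the series" means these compounds.

Compound 1 `Cc1cc(C(=O)Nc2ccccc2)nn1Cc1cc(Cl)ccc1OCc1ccccc1`: > 3.7 (a limit of the assay)
Compound 2 `Cc1cc(C(=O)Nc2cccc(F)c2)nn1Cc1cc(Cl)ccc1OCc1ccccc1`: 2.8
Compound 3 `Cc1cc(C(=O)NCc2cccnc2)nn1Cc1cc(Cl)ccc1OCc1ccccc1`: > 3.7 (a limit of the assay)

In a physicochemical assay for lipophilicity, at pH 7.4 (on this read-out higher numbers stand for higher lipophilicity and lower numbers for lower lipophilicity), compound 1 gives > 3.7, which is a limit of the assay and not a number. Compound 2 gives 2.8. Compound 3 gives > 3.7, again a limit. Compound 4 `Cc1cc(C(=O)NCc2ccncc2)nn1Cc1cc(Cl)ccc1OCc1ccccc1` differs from compound 1 by (pyridin-4-yl)methyl in place of phenyl on an amide-type nitrogen. The closest measured step is a step that the two limits leave unreadable from compound 1 to compound 3, so its size is not readable; the step of a number at least 0.90 log units higher from compound 2 to compound 3 (beyond the scatter) shows at least a modest rise, and the limit of > 3.7 in this assay, at which 2 of the 3 values shown sit, marks where two of the three values sit. For compound 4 the estimate is therefore 3.9, between 3.3 and 4.5. That expected outcome means a step that the limit leaves unreadable from compound 1 to compound 4, with a good chance that only a limit is reported.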

Compound 4, distribution coefficient: > 3.7
Compound 4: a limit, no number; the forecaster's own chance of this, stated with the estimate: 65%; the middle value does not contradict the limit.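

Putting pyridin-4-yl in place of pyridin-3-yl on the saturated chain carbon still gives no number: the reading for compound 4 is a limit of the assay. In this assay, going by these compounds alone, the only readable new step is a number at least 0.90 log units higher from compound 2 to compound 4 (beyond the scatter), and the steps to compound 4 from compound 1 and from compound 3 cannot be read. On the amide-type nitrogen, neither (pyridin-3-yl)methyl nor (pyridin-4-yl)methyl gives a number, and the values crowd at one limit: the limit of > 3.7 in this assay, at which 3 of the 4 values shown sit.

Going by these compounds, how far compound 3 and compound 4 really lie apart stays open. So does whether an amine or a carboxylic acid in place of the (pyridin-4-yl)methyl group would give a reading inside the range.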